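The compounds below may be only part of what the source reports. "The series", "measured", "known", "first", "only" and "open" are said of these compounds alone.

Within the data shown here, in a functional assay with Homo sapiens as the target (a lower number here means a stronger inhibitor, a higher number a weaker inhibitor), three compounds on a shared core have numbers so far. Compound 1 (`CC(C)[C@H](NC(=O)COc1cccc2ccccc12)C(=O)N[C@@H](CC(=O)O)C(=O)COc1cc(F)ccc1F`) gives 19700 nM, compound 2 (`CC(C)[C@H](NC(=O)COc1cccc2ccccc12)C(=O)N[C@@H](CC(=O)O)C(=O)COc1cc(F)c(F)cc1F`) gives 16700 nM, and compound 3 (`CC(C)[C@H](NC(=O)COc1cccc2ccccc12)C(=O)N[C@@H](CC(=O)O)C(=O)COc1c(F)c(F)cc(F)c1F`) gives 6250 nM, the lowest of the three. Compound 4 (`CC(C)[C@H](NC(=O)COc1cccc2ccccc12)C(=O)N[C@@H](CC(=O)O)C(=O)COc1c(F)c(F)c(-c2c(F)c(F)c(F)c(F)c2F)c(F)c1F`) departs from compound 3 at one place: 2,3,4,5,6-pentafluorophenyl in place of hydrogen on an aromatic carbon. Among the measured compounds shown here, the steps that bear on this change all concern the fluorinated ring. There is a 1.2-fold lower number from compound 1 to compound 2 (0.07 log units; within the scatter), which lies within the scatter, and the modest 2.7-fold lower number from compound 2 to compound 3 (0.43 log units; beyond the scatter) and a 3.2-fold lower number from compound 1 to compound 3 (0.50 log units; beyond the scatter). None of them adds a second ring, so they give no firm direction, and no step beyond the scatter is expected in this assay. For compound 4 the estimated value is 6000 nM, with an expected range from 1500 nM to 25000 nM.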

Compound 4, half-maximal inhibitory concentration: 40000 nM
For compound 4 the middle estimate is 6.7-fold (0.82 log units) below the measured one; measured number outside the range, above it.
By their numbers in this assay, from the lowest: compound 3; then compounds 2 and 1 (each within the scatter of the next); then compound 4.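

On this aromatic carbon, para to a large group, the earlier changes exchanged only hydrogen and fluoro, whereas 2,3,4,5,6-pentafluorophenyl adds a second ring of 11 heavy atoms. In this assay, among these compounds, this gives a 6.4-fold higher number from compound 3 to compound 4 (0.81 log units; beyond the scatter) and is the first change on this ring to raise the number beyond the scatter. No measurement at hand explains the rise.

Going by these compounds, it remains open whether a smaller group on this carbon, such as fluoro, methyl or an amine, would keep the lower number. On these data alone, whether an unfluorinated phenyl would behave like 2,3,4,5,6-pentafluorophenyl also remains open.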